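The source may hold more compounds than are shown below. What is called first, only, known or untested is meant among the compounds shown, and "the series" means these compounds.

Compound 1 `CC/N=C(\S)CCn1nc(-c2ccccc2)ccc1=O` — 50.3%
Compound 2 `Cc1ccc(=O)n(CCCCC(=N)S)n1` — 29.5%
Compound 3 `COc1ccc(-c2ccc(=O)n(CCC(=N)S)n2)cc1` — 20.7%

In a functional assay on the whole organism (stomach) for inhibition, with Rattus norvegicus as the target, at a dose of 100 mg/kg by the intraduodenal route (a lower number here means less inhibition, a higher number more inhibition at the dose given (going by the name of the read-out)), compound 1 gives 50.3%, the highest of the three numbers. Compound 2 gives 29.5%, which lies beyond the scatter below compound 1, and compound 3 gives 20.7%, further below still. Compound 4 `C/N=C(/S)CCCCCn1nc(-c2ccccc2)ccc1=O` is not yet measured. It differs from compound 1 by a group of 7 heavy atoms (5 carbon, 1 nitrogen, 1 sulfur; no ring) in place of a group of 5 heavy atoms (3 carbon, 1 nitrogen, 1 sulfur; no ring), on a saturated chain carbon, two bonds along the chain from an aromatic nitrogen. Within the data shown here, no step between two measured compounds that differ in one place is available, so the effect of this change cannot be read from any measured pair. The expectation for compound 4 is a step from compound 1 of a number 12.3 percentage points lower from compound 1 to compound 4 (beyond the scatter), downward and of moderate size, with wide uncertainty. The estimate for compound 4 in this assay is 38%, expected within 18% to 58%.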

Compound 4, a percentage reported as inhibition, in the whole organism at one dose (the size of the read-out at that dose, not a potency): 92.3%
Estimate against measurement, compound 4: 54.3 percentage points below; measured number above the stated range.
By their numbers in this assay, from the lowest: compounds 3 and 2 (each within the scatter of the next); then compound 1; then compound 4.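

In this assay, among these compounds, the step of a number 42 percentage points higher from compound 1 to compound 4 (beyond the scatter) gives the first reading at this place, on a saturated chain carbon, two bonds along the chain from an aromatic nitrogen, since the earlier compounds offered no pair differing in one place. It shows that a group of 7 heavy atoms in place of a group of 5 heavy atoms raises the inhibition sharply on the core of compound 1. Nothing shown accounts for this rise. From the compounds shown here alone, whether a longer chain, an amine or a carboxylic acid at this place would raise or lower the number stays open. A single step also leaves open whether the same change would act alike on another core.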